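The compounds below may be only part of what the source reports. "The series", "measured", "known", "first", "only" and "open" are said of these compounds alone.

Measured in a physicochemical assay for lipophilicity, measured as octanol-water partition; a lower number here means a more polar compound, a higher number a more lipophilic compound:
- compound 1 `O=C(NNc1ccnc2cc(Cl)ccc12)c1ccccc1/N=C/c1ccc(Cl)cc1`: 5.62
- compound 2 `COc1ccc(/C=N/c2ccccc2C(=O)NNc2ccnc3cc(Cl)ccc23)cc1`: 5
- compound 3 `COc1cc(/C=N/c2ccccc2C(=O)NNc2ccnc3cc(Cl)ccc23)cc(OC)c1OC`: 4.94

Compound 2 at 5 lies within the scatter of compound 3 at 4.94, and clearly under compound 1 at 5.62. Compound 4 `O=C(NNc1ccnc2cc(Cl)ccc12)c1ccccc1/N=C/c1ccncc1` comes from compound 2 by one change: pyridin-4-yl in place of 4-methoxyphenyl on a carbon with a double bond to nitrogen. Among the compounds with values here, the only measured step, a number 0.62 log units lower from compound 1 to compound 2 (beyond the scatter), is a different swap, methoxy in place of chloro on an aromatic carbon, so it is a loose guide. Within the data shown here, no measured step brings in pyridin-4-yl, so the size is a judgement: a fall somewhat larger than that step is expected, a number 1.00 log units lower from compound 2 to compound 4 (beyond the scatter). For compound 4 the estimated value is 4, with an expected range of 3.4 to 4.6.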

Compound 4, partition coefficient: 3.86
Compound 4: the middle estimate sits 0.14 log units above what was measured; measured number inside the range.
By their numbers in this assay, from the lowest: compound 4; then compounds 3 and 2 (each within the scatter of the next); then compound 1.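

Within the data shown here, at this carbon with a double bond to nitrogen, the earlier compounds all kept a carbon-only aromatic ring and differed only in what that ring carried, whereas compound 4 has pyridin-4-yl, with a nitrogen in the ring itself. In this assay this change gives a number 1.14 log units lower from compound 2 to compound 4 (beyond the scatter) and a number 1.76 log units lower from compound 1 to compound 4 (beyond the scatter) as large steps, against the modest a number 0.62 log units lower from compound 1 to compound 2 (beyond the scatter) seen when only the group on the ring changed. On these data alone, whether an amine or a carboxylic acid on the ring would move the number as far remains open. Nothing shown explains the size of these steps.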